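This account rests on a few compounds, and the source may have more. Where it says the series, first, only, none or still open, it means among the compounds named here.

In a functional assay on cells (Homo sapiens) for antiproliferative activity, read by sulforhodamine B assay, with a stated time of 48 h (on this read-out higher numbers stand for weaker inhibition and lower numbers for stronger inhibition), compound 1 (`CCCCCCCCNC(=O)[C@@H]1CSC(c2cc(OC)c(OC)c(OC)c2)N1`) gives 17100 nM and compound 2 (`CCCCCCCCCCNC(=O)[C@@H]1CSC(c2cc(OC)c(OC)c(OC)c2)N1`) gives 14500 nM, so compound 2 stands level with compound 1 within the scatter. Compound 3 (`CCCCCCCCCCCCNC(=O)[C@@H]1CSC(c2cc(OC)c(OC)c(OC)c2)N1`) differs from compound 2 on the chain: ethyl in place of hydrogen on a saturated chain carbon, ten or more bonds along the chain from an amide-type nitrogen. Within the data shown here, one measured step bears on this, the same ethyl in place of hydrogen eight bonds along the chain from an amide-type nitrogen: a 1.2-fold lower number from compound 1 to compound 2 (0.07 log units; within the scatter). Among the measured compounds shown here, with only that step as a guide, no change beyond the scatter is expected in this assay. The expected step is a 1.1-fold lower number from compound 2 to compound 3 (0.05 log units; within the scatter). For compound 3 the estimated value is 13000 nM, with an expected range of 6000 nM to 28000 nM.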

Compound 3, half-maximal inhibitory concentration: 2100 nM
The estimate for compound 3 lay 6.2-fold (0.79 log units) above the measured number, and the stated range ends above it.
By their numbers in this assay, from the lowest: compound 3; then compounds 2 and 1 (each within the scatter of the next).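

In this assay the chain is not flat at this position: ethyl in place of hydrogen on a saturated chain carbon gives a clear step (a 6.9-fold lower number from compound 2 to compound 3 (0.84 log units; beyond the scatter)), whereas the same change eight bonds along stayed within the scatter. Butyl in place of hydrogen, eight bonds along the chain, gives a step of similar size (an 8.1-fold lower number from compound 1 to compound 3 (0.91 log units; beyond the scatter)), so the drop among these three compounds rests on the last extension. No measured evidence bears on the reason for this.

Open: whether a longer chain lowers the number further or reverses the trend, and whether an amine or a carboxylic acid in place of the ethyl retains the step.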